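An aryl swap in a series sitting at its limit

A few compounds are considered here, and "the series" means these few. Any claim that something is new, unique, unknown or untested is made for them only; others in the source may bear on it.

Measured so far in a functional assay on ECV-304 cells (Homo sapiens) for cytotoxicity; on this read-out higher numbers stand for weaker inhibition and lower numbers for stronger inhibition:
- compound 1 `Cc1cccc(/C=C2\SC(=S)N(NS(=O)(=O)c3ccccc3)C2=O)c1`: > 50000 nM, a limit
- compound 2 `O=S(=O)(NN1C(=S)S/C(=C\c2ccc(Cl)c(Cl)c2)C1O)c1ccc(Cl)cc1`: > 50000 nM, a limit

Compound 1 stands at the limit of > 50000 nM in this assay, at which 2 of the 2 values shown sit. Among the measured compounds shown here, neither compound has a numerical value, and no step between measured compounds is available.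

The next compound to be measured is compound 3 `O=C1/C(=C/c2ccc(Cl)c(F)c2)SC(=S)N1NS(=O)(=O)c1ccccc1`, which keeps the core of compound 1 and changes one group: 4-chloro-3-fluorophenyl in place of 3-methylphenyl on a double-bonded chain carbon bound to a double-bonded ring carbon. In words, this places 4-chloro-3-fluorophenyl in place of 3-methylphenyl on a double-bonded chain carbon bound to a double-bonded ring carbon.

For the measured compounds named here, with no measured step to draw on, no change beyond the usual scatter is expected in this assay, and neither direction is favoured. This expectation rests on compound 1, whose reading of > 50000 nM is a limit. The expected change is a number no higher from compound 1 to compound 3 (the limit leaves the size open). For compound 3 the estimated value is 50000 nM, with an expected range of 20000 nM to 100000 nM. A further limit in place of a number would fit this expectation.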

Compound 3, half-maximal inhibitory concentration: > 50000 nM
Compound 3: a limit, no number; the forecaster's own chance of this, stated with the estimate: 70%; the middle value sits exactly at the limit.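

The step from compound 1 to compound 3 cannot be read, as both readings are limits and not numbers. All readings so far sit together: the limit of > 50000 nM in this assay, at which 3 of the 3 values shown sit.

The compounds shown leave open how 4-chloro-3-fluorophenyl and 3-methylphenyl compare in this assay, and whether any compound of this series gives a numerical value there.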